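Ester variations on a shared quinolinone core and tolerated concentration

The compounds below may be only part of what the source reports. "The series", "measured", "known", "first", "only" and "open" are said of these compounds alone.

Measured compounds:
compound 1 `COCC(=O)OCCc1c(-c2ccccc2Cl)c2cc(Cl)ccc2[nH]c1=O`: 74000 nM
compound 2 `O=C(CCC1CCCCC1)OCCc1c(-c2ccccc2Cl)c2cc(Cl)ccc2[nH]c1=O`: 160000 nM
compound 3 `COc1ccccc1/C=C/C(=O)OCCc1c(-c2ccccc2Cl)c2cc(Cl)ccc2[nH]c1=O`: 770000 nM

In an ADME assay on HepG2 2.2.15 cells (Homo sapiens) for cytotoxicity (a higher number here means that more compound is tolerated, a lower number that less compound is tolerated), compound 1 gives the lowest of the three numbers; its nearest neighbour is compound 2, with a 2.2-fold higher number from compound 1 to compound 2 (0.33 log units; beyond the scatter), and the furthest is compound 3, with a 10-fold higher number from compound 1 to compound 3 (1.02 log units; beyond the scatter). Between the two larger esters the step is a 4.8-fold higher number from compound 2 to compound 3 (0.68 log units; beyond the scatter).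

Compound 4 `COc1cccc(/C=C/C(=O)OCCc2c(-c3ccccc3Cl)c3cc(Cl)ccc3[nH]c2=O)c1` has not yet been measured. Its structure differs from that of compound 1 as follows: 2-(3-methoxyphenyl)ethenyl in place of methoxymethyl on a carbonyl carbon

Going by the values given here, the step that bears most directly on this change is the one to compound 3, since that compound also carries a methoxyphenyl-substituted ethenyl group on the carbonyl carbon and the move from compound 1 was large in this assay, a 10-fold higher number from compound 1 to compound 3 (1.02 log units; beyond the scatter). Compound 2 shows that a bulkier ester alone already gives a modest rise, a 2.2-fold higher number from compound 1 to compound 2 (0.33 log units; beyond the scatter). A large upward step in this assay is therefore expected for compound 4, a 6.8-fold higher number from compound 1 to compound 4 (0.83 log units; beyond the scatter). Compound 4 is estimated at 500000 nM, with a range from 150000 nM to 1500000 nM, because the closely related compound 3 gave 770000 nM.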

Compound 4, half-maximal cytotoxic concentration: > 1300000 nM
Compound 4: only a limit was reported; the forecaster's own chance of this, stated with the estimate: 25%; middle value at least 2.6-fold (0.41 log units) away from the limit.
By their numbers in this assay, from the lowest: compound 1; then compound 2; then compound 3. At a limit, above all of these: compound 4.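

In this assay compound 4 gives a limit and not a number: the limit of > 1300000 nM in this assay, at which 1 of the 4 values shown sits. The change of 3-methoxyphenyl for 2-methoxyphenyl on the double-bonded chain carbon leaves the comparison unsettled (an at least 1.6-fold higher number from compound 3 to compound 4 (0.22 log units; that floor lies within the scatter)), so these compounds do not show whether the placing of the methoxy group matters. What compound 4 adds is that a large rise over the methoxymethyl ester (an at least 17-fold higher number from compound 1 to compound 4 (1.24 log units; beyond the scatter)) is not confined to compound 3, and that it also stands clear of the 2-cyclohexylethyl ester (an at least 8.1-fold higher number from compound 2 to compound 4 (0.90 log units; beyond the scatter)).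

As far as these compounds go, how far the true number for compound 4 lies past its limit remains open, and with it any ranking of the two methoxyphenyl esters. Also open, from the compounds shown here alone, is whether the rise would survive an amine or a carboxylic acid in place of the methoxy group, or a longer chain in place of the ethenyl link.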